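Capping a Long Amide Chain with an Acetamido Group

The compounds below may be only part of what the source reports. "The series", "measured", "known", "first", "only" and "open" are said of these compounds alone.

Of the compounds shown here, three built on a shared core have been measured in an assay on cell membranes for binding affinity to 2-oxoglutarate receptor 1 (Rattus norvegicus), read by radioligand binding; on this read-out higher numbers stand for weaker inhibition and lower numbers for stronger inhibition. Compound 1 `NC(=O)[C@H]1OC(n2cnc3c(N)ncnc32)[C@H](O)[C@@H]1O`, which carries a hydrogen on the amide-type nitrogen, gives 64 nM. Compound 2 `CCCCCCCNC(=O)[C@H]1OC(n2cnc3c(N)ncnc32)[C@H](O)[C@@H]1O` gives 20 nM, and compound 3 `CCCCCCCCCNC(=O)[C@H]1OC(n2cnc3c(N)ncnc32)[C@H](O)[C@@H]1O` gives 31 nM. Among these three numbers compound 3 holds the second highest; its nearest neighbour is compound 2, with a 1.6-fold higher number from compound 2 to compound 3 (0.19 log units; within the scatter), and its furthest is compound 1, with a 2.1-fold lower number from compound 1 to compound 3 (0.31 log units; beyond the scatter). The remaining step, a 3.2-fold lower number from compound 1 to compound 2 (0.51 log units; beyond the scatter), is also modest.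

Compound 4 `CC(=O)NCCCCCCCCNC(=O)[C@H]1OC(n2cnc3c(N)ncnc32)[C@H](O)[C@@H]1O` has not yet been measured. Relative to compound 3 the change is acetamido in place of methyl on a saturated chain carbon, eight bonds along the chain from an amide-type nitrogen. For the measured compounds named here, none of the measured steps introduces an acetamido group, so the expectation rests on the steps in which the chain itself was altered. The step of a 1.6-fold higher number from compound 2 to compound 3 (0.19 log units; within the scatter) shows that adding to the chain left the number within the scatter, while a 3.2-fold lower number from compound 1 to compound 2 (0.51 log units; beyond the scatter) and a 2.1-fold lower number from compound 1 to compound 3 (0.31 log units; beyond the scatter) show that the chain as a whole lowers the number only modestly. For compound 4 a step within the scatter is therefore expected, with no clear direction, a 1.1-fold higher number from compound 3 to compound 4 (0.05 log units; within the scatter). The estimate for compound 4 in this assay is 35 nM, with a range from 12 nM to 100 nM.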

Compound 4, inhibition constant: 10 nM
Beside the measured number, compound 4's estimate is 3.5-fold (0.54 log units) above it; the whole stated range lies above it.
By their numbers in this assay, from the lowest: compounds 4, 2 and 3 (each within the scatter of the next, the first and the last beyond it); then compound 1.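

In this assay, acetamido in place of methyl on a saturated chain carbon, eight bonds along the chain from an amide-type nitrogen, gives a 3.1-fold lower number from compound 3 to compound 4 (0.49 log units; beyond the scatter) and so shows that the group carried at this place can shift the number beyond the scatter, which simply lengthening the chain had not done. Acetamidomethyl in place of hydrogen on a saturated chain carbon, seven bonds along the chain from an amide-type nitrogen, gives a 2.0-fold lower number from compound 2 to compound 4 (0.30 log units; within the scatter) and so leaves compound 2 and compound 4 level, which means the acetamido-capped chain separates from the nonyl chain of compound 3 but not from the heptyl chain of compound 2. The data shown offer no measurement that would explain this shift.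

The compounds shown leave open whether the acetamido group as a whole matters or whether a simpler group at the same place, such as an amine or a carboxylic acid, would give a similar number. They also leave open how the number responds when the acetamido group sits on a shorter or a longer chain.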